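The source may report more compounds than this note shows. Statements on the series, on what has been measured and on what is new or still open speak of the compounds shown alone.

Measured in a functional assay on A549 cells (Homo sapiens) for cytotoxicity, read by sulforhodamine B assay, with a stated time of 48 h; a lower number here means a stronger inhibitor, a higher number a weaker inhibitor:
- compound 1 `COc1cc(/C=C/C(=O)c2cccc(-c3cccc(F)c3)c2)ccc1O`: 9900 nM
- compound 2 `COc1ccccc1/C=C/C(=O)c1cccc(-c2cccc(F)c2)c1`: 15500 nM
- compound 3 `COc1ccc(-c2cc(C(=O)/C=C/c3cc(OC)c(OC)c(OC)c3)ccc2N)cc1OC`: 4620 nM

Compound 3 has the lowest number of the three, beyond the scatter from both others. Compound 4 `COc1cc(/C=C/C(=O)c2ccc(N)c(-c3ccc(F)cc3)c2)cc(OC)c1OC` differs from it in one place: 4-fluorophenyl in place of 3,4-dimethoxyphenyl on an aromatic carbon, with 4-fluorophenyl in place of 3,4-dimethoxyphenyl on an aromatic carbon, ortho to an amino group. Going by the values given here, no measured pair isolates this change. Compound 1 at 9900 nM and compound 2 at 15500 nM also carry a fluorophenyl group, but they differ from compound 3 elsewhere too, so they offer only a weak hint. A small upward move in this assay is expected, a 1.3-fold higher number from compound 3 to compound 4 (0.11 log units; within the scatter), probably within the scatter. For compound 4 the estimated value is 6000 nM, with an expected range of 2200 nM to 15000 nM.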

Compound 4, half-maximal inhibitory concentration: 6070 nM
Compound 4: the middle estimate sits 1.0-fold (0.01 log units) below what was measured; the measured number falls inside the stated range.
By their numbers in this assay, from the lowest: compounds 3, 4, 1 and 2 (each within the scatter of the next, the first and the last beyond it).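

In this assay, 4-fluorophenyl in place of 3,4-dimethoxyphenyl on an aromatic carbon, ortho to an amino group, gives a 1.3-fold higher number from compound 3 to compound 4 (0.12 log units; within the scatter). This first matched pair shows that the assay does not separate these two groups at this position, even though the entering group has fewer heavy atoms and no hydrogen-bond acceptors. No available evidence accounts for this result. Still open, as far as these compounds go, is whether a smaller or more polar substituent here, such as a chlorine, a hydroxyl or a morpholine, would also stay within the scatter. Also open, from the compounds shown here alone, is how an acetamide in place of the amino group would read.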